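From cyclopropyl to propyl: one small change

A few compounds are considered here, and "the series" means these few. Any claim that something is new, unique, unknown or untested is made for them only; others in the source may bear on it.

Compound 1 `c1ccc(/C(=N/Nc2nc3ccccc3o2)C2CC2)nc1` gives 185 nM
Compound 2 `C/C(=N\Nc1nc2ccccc2o1)c1ccc2ccccc2n1` gives 5490 nM

In a functional assay on cells (Burkitts lymphoma cell, Homo sapiens) for antiproliferative activity, read by MTT assay (on this read-out lower numbers stand for stronger inhibition and higher numbers for weaker inhibition), compound 1 holds the lower of the two numbers, and the gap up to compound 2 lies beyond the usual scatter. Compound 2 differs from compound 1 in more than one place, so this pair does not show what any single change does.

The next molecule, compound 3 `CCC/C(=N\Nc1nc2ccccc2o1)c1ccccn1`, has not been measured yet. It keeps the core of compound 1 and carries propyl in place of cyclopropyl on a carbon with a double bond to nitrogen. For the measured compounds named here, no measured pair here shows this swap, so the expectation rests on compound 1 (185 nM) and on how little the structure changes. In this assay a modest rise toward weaker inhibition is expected, no larger than the scatter (estimated a 1.6-fold higher number from compound 1 to compound 3 (0.21 log units; within the scatter)). For compound 3 the estimated value is 300 nM (expected range 100 nM to 1000 nM).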

Compound 3, half-maximal inhibitory concentration: 6 nM
Estimate against measurement, compound 3: 50-fold (1.70 log units) above; measured number below the stated range.
By their numbers in this assay, from the lowest: compound 3; then compound 1; then compound 2.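

In this assay, this position proves far from neutral: propyl in place of cyclopropyl gives a 31-fold lower number from compound 1 to compound 3 (1.49 log units; beyond the scatter) even though the number of heavy atoms stays the same. The two groups also match in their counts of hydrogen-bond donors and acceptors and in having no net charge, so the computed comparison leaves the ring as the one listed difference between them, and a simple atom count does not predict the outcome at this carbon. This single pair shows that the open chain gives the stronger inhibition here, but no measurement is available to explain the size of the step, so its cause remains unknown.

The compounds shown do not tell whether the gain would continue with a longer chain such as pentyl, survive branching as in isopropyl, or hold with an amine at the end of the chain. Compound 2 differs from the others in more than one place, so it cannot show how far the shared core and the group at this carbon each contribute to the activity.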